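The compounds below may be only part of what the source reports. "The series", "measured", "known", "first", "only" and "open" are said of these compounds alone.

Compound 3 `Cc1cc(=O)n(-c2ccc(Br)cc2F)nc1C(=O)Nc1ccc(Oc2ncnc3sccc23)c(F)c1` is the starting point. In a functional assay on A549 cells (Homo sapiens) for cytotoxicity, read by MTT assay, with a stated time of 72 h (on this read-out higher numbers stand for weaker inhibition and lower numbers for stronger inhibition), compound 3 gives 11500 nM, which is the second highest of the three numbers available: its nearest neighbour is compound 2 `Cc1cc(=O)n(-c2ccc(Br)cc2F)nc1C(=O)Nc1ccc(Oc2ncnc3sccc23)cc1`, which in this assay gives 12800 nM, and the farthest is compound 1 `Cc1cc(=O)n(-c2ccc(Br)cc2F)nc1C(=O)Nc1ccc(Oc2ncnc3ccsc23)c(F)c1`, which in this assay gives 2980 nM.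

Two measured steps lead into compound 3. The swap of the fused bicyclic group on the ether oxygen gives a 3.9-fold higher number from compound 1 to compound 3 (0.59 log units; beyond the scatter). The added fluoro on the aromatic carbon gives a 1.1-fold lower number from compound 2 to compound 3 (0.05 log units; within the scatter).

Compound 4 `Cc1cc(=O)n(-c2ccc(F)cc2)nc1C(=O)Nc1ccc(Oc2ncnc3sccc23)c(F)c1` arises from compound 3 by the change (4-fluorophenyl in place of 4-bromo-2-fluorophenyl on an aromatic nitrogen). Among the compounds with values here, neither measured step touches the group on the aromatic nitrogen, so nothing measured bears directly on this change; the one step beyond the scatter concerns the other end of the molecule, and the other lies within it. Without a comparable step to lean on, compound 4 is expected to stay close to compound 3, with a step of a 1.0-fold lower number from compound 3 to compound 4 (0.02 log units; within the scatter) in this assay. Compound 4 is therefore estimated at 11000 nM, within a range from 3500 nM to 35000 nM.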

Compound 4, half-maximal inhibitory concentration: 2620 nM
Estimate against measurement, compound 4: 4.2-fold (0.62 log units) above; the whole stated range lies above it.
By their numbers in this assay, from the lowest: compounds 4 and 1 (each within the scatter of the next); then compounds 3 and 2 (each within the scatter of the next).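

In this assay, within the data shown here, the change to 4-fluorophenyl on the aromatic nitrogen gives a 4.4-fold lower number from compound 3 to compound 4 (0.64 log units; beyond the scatter), which shows that the read-out responds to this aryl group, a part of the molecule no earlier step had touched. This step lies beyond the scatter, whereas the added fluoro at the other end of the molecule, with a 1.1-fold lower number from compound 2 to compound 3 (0.05 log units; within the scatter), does not. Nothing available accounts for the size or direction of the step.

The bromine and one fluorine leave together in this single change, so the compounds shown do not reveal which loss carries the step, or whether both are needed. From the compounds shown here alone, how a plain phenyl, a 4-methoxyphenyl or a 4-aminophenyl on the same nitrogen would read also remains open, as does whether the 4-fluorophenyl gives a similar step with the fused group of compound 1.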